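A few compounds are considered here, and "the series" means these few. Any claim that something is new, unique, unknown or untested is made for them only; others in the source may bear on it.

In a functional assay on HeLa cells (Homo sapiens) for inhibition, read by sulforhodamine B assay (a higher number here means a weaker inhibitor, a lower number a stronger inhibitor), compound 1, with structure `COc1cccc(NC2=CC(=O)c3nc4n(c3C2=O)[C@H]2OC[C@@H](O)[C@H]2OC4)c1`, gives 4280 nM. Two close relatives help place it: compound 2, `CCOc1ccccc1NC1=CC(=O)c2c(nc3n2[C@H]2OC[C@@H](O)[C@H]2OC3)C1=O`, gives 8300 nM, and compound 3, `O=C1C(Nc2ccccc2F)=CC(=O)c2c1nc1n2[C@H]2OC[C@@H](O)[C@H]2OC1`, gives 9820 nM. The gap between compound 1 and compound 2 lies within the scatter, while compound 3 sits beyond it. Among the measured compounds shown here, the only step among measured pairs, a 1.2-fold higher number from compound 2 to compound 3 (0.07 log units; within the scatter), concerns a different change.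

Compound 4, `COc1ccc(NC2=CC(=O)c3nc4n(c3C2=O)[C@H]2OC[C@@H](O)[C@H]2OC4)cc1`, is unmeasured. It differs from compound 1 by 4-methoxyphenyl in place of 3-methoxyphenyl on an amine nitrogen. For the measured compounds named here, no measured step tests moving the methoxy around the ring, so no change beyond the scatter is expected; the estimated step of a 1.0-fold higher number from compound 1 to compound 4 (0.00 log units; within the scatter) is small. Compound 4 is therefore expected to give about 4300 nM, between 1500 nM and 13000 nM.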

Compound 4, half-maximal inhibitory concentration: 4780 nM
The estimate for compound 4 lay 1.1-fold (0.05 log units) below the measured number, and the stated range covers the measured number.
By their numbers in this assay, from the lowest: compounds 1, 4, 2 and 3 (each within the scatter of the next, the first and the last beyond it).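

In this assay, placing the methoxy differently, with 4-methoxyphenyl in place of 3-methoxyphenyl on the amine nitrogen, gives a 1.1-fold higher number from compound 1 to compound 4 (0.05 log units; within the scatter). Among the compounds shown here, this is the first measured pair to test where a group sits on this ring, rather than which group is there, and the two placements cannot be told apart. Nothing available here explains this likeness. Still open, on these data alone, is whether a carboxylic acid or an amine in place of the methoxy would shift the number beyond the scatter.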